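A few compounds are considered here, and "the series" means these few. Any claim that something is new, unique, unknown or untested is made for them only; others in the source may bear on it.

Measured so far in an ADME assay on Vero cells (Chlorocebus sabaeus) for cytotoxicity, read by fluorescence and resazurin assay, with a stated time of 3 days; a higher number here means that more compound is tolerated, a lower number that less compound is tolerated:
- compound 1 `COc1ccc(N/N=C2\C(=O)N(Cc3cn(C[C@H]4O[C@@H]5OC(C)(C)O[C@@H]5[C@H]4O)nn3)c3ccccc32)cc1`: 74500 nM
- compound 2 `O=C1/C(=N\Nc2ccccc2)c2ccccc2N1Cc1cn(O[C@@H]2O[C@H](CO)[C@H](O)[C@H](O)[C@H]2O)nn1`: 83400 nM
- compound 3 `O=C1/C(=N\Nc2ccc(Br)cc2)c2ccccc2N1Cc1cn(O[C@@H]2O[C@H](CO)[C@H](O)[C@H](O)[C@H]2O)nn1`: 91500 nM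

Compound 3 has the highest of the three numbers in this assay, but its distance to compound 2 and to compound 1 lies within the scatter of the assay, so the three compounds cannot be told apart on these values.

Compound 4 `COc1ccc(N/N=C2\C(=O)N(Cc3cn(O[C@@H]4O[C@H](CO)[C@H](O)[C@H](O)[C@H]4O)nn3)c3ccccc32)cc1` is not yet measured. It differs from compound 3 in one place: methoxy in place of bromo on an aromatic carbon.

Among the measured compounds shown here, only one measured step bears on this change. It is a 1.1-fold higher number from compound 2 to compound 3 (0.04 log units; within the scatter), and it shows that putting a bromo on the aromatic carbon of compound 2 moved the number no further than the scatter. For the measured compounds named here, no measured pair shows the methoxy entering at this place on this sugar; compound 1 carries a methoxy at the same place but also a different sugar part, and its value sits within the scatter of compound 3. Taken together, the change from compound 3 to compound 4 is expected to give no step beyond the scatter, which is what a 1.1-fold lower number from compound 3 to compound 4 (0.05 log units; within the scatter) expresses.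

Compound 4 is therefore estimated at 82000 nM in this assay, with a likely range from 50000 nM to 135000 nM.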

Compound 4, half-maximal cytotoxic concentration: 76200 nM
Compound 4: middle estimate off by 1.1-fold (0.03 log units), on the high side; low and high end bracket the measured number.
By their numbers in this assay, from the lowest: compounds 1, 4, 2 and 3 (each within the scatter of the next).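

In this assay the methoxy can now be read directly at this place on this sugar: in place of bromo it gives a 1.2-fold lower number from compound 3 to compound 4 (0.08 log units; within the scatter) and in place of hydrogen it gives a 1.1-fold lower number from compound 2 to compound 4 (0.04 log units; within the scatter) so hydrogen, bromo and methoxy on this aromatic carbon cannot be told apart. With the methoxy held fixed, exchanging the group on the aromatic nitrogen gives a 1.0-fold higher number from compound 1 to compound 4 (0.01 log units; within the scatter) so this second place also shows no step beyond the scatter. No measured evidence offers an explanation for these results.

From the compounds shown here alone, whether an amine or a carboxylic acid on this aromatic carbon would move the number beyond the scatter remains open. It is also open whether bromo or hydrogen would behave like methoxy with the sugar part of compound 1, where only methoxy is shown.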